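Methyl to Ethyl on the Thiadiazole Arm of Compound 1

A few compounds are considered here, and "the series" means these few. Any claim that something is new, unique, unknown or untested is made for them only; others in the source may bear on it.

Measured compounds in a functional assay on PANC-1 cells (Homo sapiens) for inhibition, read by MTT assay, with a stated time of 48 h; on this read-out lower numbers stand for stronger inhibition and higher numbers for weaker inhibition:
- compound 1 `Cc1nnsc1CO/N=C/c1c(C)nn(C)c1Oc1ccccc1Cl`: > 50000 nM
- compound 2 `Cc1nnsc1CO/N=C/c1c(C)nn(C)c1Oc1ccc(Br)cc1`: 12800 nM
- compound 3 `Cc1nnsc1CO/N=C/c1c(C)nn(C)c1Oc1cc(F)cc(F)c1`: > 50000 nM

In this assay compound 1 gives > 50000 nM, which is a limit of the assay and not a number. Compound 3 likewise gives > 50000 nM, also a limit. Among the compounds with values here, compound 2 gives 12800 nM, the only value of the three that is a number; it is reached by an at least 3.9-fold lower number from compound 1 to compound 2 (0.59 log units; beyond the scatter), and lost again by an at least 3.9-fold higher number from compound 2 to compound 3 (0.59 log units; beyond the scatter), while a step that the two limits leave unreadable from compound 1 to compound 3. Two of the three values share (the limit of > 50000 nM in this assay, at which 2 of the 3 values shown sit).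

Compound 4 `CCc1nnsc1CO/N=C/c1c(C)nn(C)c1Oc1ccccc1Cl` differs from compound 1 by methyl in place of hydrogen on a saturated chain carbon bound to an aromatic carbon. Within the data shown here, every measured step changes the aryl group on the ether oxygen; none touches the thiadiazole side of the shared core, so there is no measured step that bears on this change. With compound 1 at the limit and no evidence for movement, compound 4 is expected to remain at the limit, with a step that the limit leaves unreadable from compound 1 to compound 4 expected to stay within the scatter. The estimate for compound 4 is 80000 nM, with an expected range from 20000 nM to 300000 nM.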

Compound 4, half-maximal inhibitory concentration: > 50000 nM
Compound 4: a limit, no number (the forecaster's own chance of this, stated with the estimate: 80%); the middle value does not contradict the limit.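

In this assay compound 4 gives > 50000 nM and this is a limit of the assay, not a number. Compound 1 also stands at a limit, so no step can be read between compound 1 and compound 4: the limit of > 50000 nM in this assay, at which 3 of the 4 values shown sit. The compounds shown leave open whether 4-ethyl-1,2,3-thiadiazol-5-yl in place of 4-methyl-1,2,3-thiadiazol-5-yl changes inhibition at all.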